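The compounds below may be only part of what the source reports. "The series", "measured", "known", "first", "only" and "open" are said of these compounds alone.

Compound 1, with the structure `Cn1cncc1CN1CC(N(Cc2cccc(-n3cccc3)c2)S(=O)(=O)c2ccccn2)Cc2cc(C#N)ccc21`, is the starting point here. In an ADME assay on Caco-2 cells (Homo sapiens) for permeability, in the apical to basolateral direction (a lower number here means that the compound crosses the layer more slowly, a higher number that the compound crosses the layer faster), compound 1 gives 2.3 10^-6 cm/s. Compound 2, with the structure `Cn1cnc(S(=O)(=O)N(Cc2cccc(-n3cccc3)c2)C2Cc3cc(C#N)ccc3N(Cc3cncn3C)C2)c1`, is built on the same core and differs from compound 1 in one place: 1-methyl-1H-imidazol-4-yl in place of pyridin-2-yl on a sulfonyl sulfur. In this assay compound 2 gives 0.2 10^-6 cm/s, and the step is a 12-fold lower number from compound 1 to compound 2 (1.06 log units; beyond the scatter).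

Compound 3, with the structure `Cn1cncc1CN1CC(N(CCn2cccc2)S(=O)(=O)c2ccccn2)Cc2cc(C#N)ccc21`, keeps the (pyridin-2-yl)sulfonyl group of compound 1 but differs from it in another place: (1H-pyrrol-1-yl)methyl in place of 3-(1H-pyrrol-1-yl)phenyl on a saturated chain carbon bound to a sulfonamide nitrogen. In this assay compound 3 gives 12.4 10^-6 cm/s, which is a 5.4-fold higher number from compound 1 to compound 3 (0.73 log units; beyond the scatter). Compound 3 thus shows the highest number of the three measured compounds, and its steps to compound 1 and compound 2 both lie beyond the scatter.

Compound 4, with the structure `Cn1cnc(S(=O)(=O)N(CCn2cccc2)C2Cc3cc(C#N)ccc3N(Cc3cncn3C)C2)c1`, has not yet been measured. It stands to compound 3 exactly as compound 2 stands to compound 1: 1-methyl-1H-imidazol-4-yl in place of pyridin-2-yl on a sulfonyl sulfur. The place of the change is the same in both pairs, a sulfonyl sulfur whose other neighbour is a sulfonamide nitrogen, so the change is the same one; the two cores differ only as described by (1H-pyrrol-1-yl)methyl in place of 3-(1H-pyrrol-1-yl)phenyl on a saturated chain carbon bound to a sulfonamide nitrogen. Since the same change once gave a 12-fold lower number from compound 1 to compound 2 (1.06 log units; beyond the scatter), a step of about that size is expected from compound 3 to compound 4, namely a 12-fold lower number from compound 3 to compound 4 (1.09 log units; beyond the scatter). Compound 4 is therefore estimated to give 1 10^-6 cm/s in this assay, with a likely range from 0.4 10^-6 cm/s to 3 10^-6 cm/s.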

Compound 4, apparent permeability: 0.3 10^-6 cm/s
Estimate against measurement, compound 4: 3.3-fold (0.52 log units) above, and the stated range ends above it.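

In this assay, 1-methyl-1H-imidazol-4-yl in place of pyridin-2-yl on the sulfonyl sulfur again lowers the number, now with a 41-fold lower number from compound 3 to compound 4 (1.62 log units; beyond the scatter), so the direction of the change carries over from one core to the other but its size does not: the same change on two cores in this assay, a 12-fold lower number (1.06 log units; beyond the scatter) from compound 1 to compound 2 and a 41-fold lower number (1.62 log units; beyond the scatter) from compound 3 to compound 4, 3.6-fold (0.56 log units) apart, beyond the scatter of two such steps The other change, (1H-pyrrol-1-yl)methyl in place of 3-(1H-pyrrol-1-yl)phenyl, gives a 1.5-fold higher number from compound 2 to compound 4 (0.18 log units; within the scatter) when the sulfonyl group carries 1-methyl-1H-imidazol-4-yl, so the size of its step also depends on the rest of the molecule: the same change on two cores in this assay, a 5.4-fold higher number (0.73 log units; beyond the scatter) from compound 1 to compound 3 and a 1.5-fold higher number (0.18 log units; within the scatter) from compound 2 to compound 4, 3.6-fold (0.56 log units) apart, beyond the scatter of two such steps Across these four compounds the two changes therefore do not simply add, which means that a step measured on one core is a guide to direction rather than a reliable figure for another, although a single square of compounds cannot show why this happens or whether it holds more widely.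

The compounds shown leave open how the sulfonyl change would behave with a longer chain, such as a propyl chain ending in the same pyrrole, in place of (1H-pyrrol-1-yl)methyl. They also leave open whether a plain phenyl or a methyl group on the sulfonyl sulfur would follow pyridin-2-yl or 1-methyl-1H-imidazol-4-yl.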